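The source may hold more compounds than are shown below. What is called first, only, known or untested is meant among the compounds shown, and "the series" means these compounds.

The study is built around a shared core that carries an aminomethyl-linked benzamide, and it asks how a single exchange on that core plays out in a functional assay on HCT-116 cells (Homo sapiens) for inhibition, read by luminescence and resazurin assay, with a stated time of 3 days; on this read-out lower numbers stand for stronger inhibition and higher numbers for weaker inhibition. Compound 1 `Cc1ccc2nc(N(C)C)nc(NCc3ccc(C(=O)NC4CCN(Cc5ccc(F)cc5)CC4)cc3)c2c1` is the anchor: in this assay compound 1 gives 800 nM. Compound 3 `Cc1ccc2nc(N3CCNC(C)C3)nc(NCc3ccc(C(=O)NC4CCN(Cc5ccc(F)cc5)CC4)cc3)c2c1` keeps everything else and differs only at one aromatic carbon, (3-methylpiperazin-1-yl in place of dimethylamino on an aromatic carbon). In this assay compound 3 gives 2000 nM, and the step of a 2.5-fold higher number from compound 1 to compound 3 (0.40 log units; beyond the scatter) is a modest loss.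

Compound 2 `CN(C)c1nc(NCc2ccc(C(=O)Nc3ccc(F)cc3)cc2)c2ccccc2n1` belongs to a second series whose benzamide is capped by a fluorophenyl rather than the substituted piperidine of compound 1; the difference between the two cores is not broken down here. In this assay compound 2 gives 1900 nM, a higher number than compound 1 shows, and one that sits close to the number of compound 3.

Compound 4 `CC1CN(c2nc(NCc3ccc(C(=O)Nc4ccc(F)cc4)cc3)c3ccccc3n2)CCN1` has not yet been measured. It stands to compound 2 as compound 3 stands to compound 1, through the same change, (3-methylpiperazin-1-yl in place of dimethylamino on an aromatic carbon). Within the data shown here, because the only precedent, a 2.5-fold higher number from compound 1 to compound 3 (0.40 log units; beyond the scatter), is a modest loss, the step from compound 2 to compound 4 is expected to be of similar size, a 2.4-fold higher number from compound 2 to compound 4 (0.37 log units; beyond the scatter). On that basis compound 4 is estimated at 4500 nM in this assay, with a likely range from 2000 nM to 10000 nM.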

Compound 4, half-maximal inhibitory concentration: 2800 nM
For compound 4 the middle estimate is 1.6-fold (0.21 log units) above the measured one, and the stated range covers the measured number.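

Carried to the second core, the exchange of dimethylamino for 3-methylpiperazin-1-yl gives a 1.5-fold higher number from compound 2 to compound 4 (0.17 log units; within the scatter) in this assay, so on this core the step does not separate the pair. Set beside the step on the first core, the second step shows no difference that can be told apart from ordinary variation, and the change carries across the two cores to that extent: the same change on two cores in this assay, a 2.5-fold higher number (0.40 log units; beyond the scatter) from compound 1 to compound 3 and a 1.5-fold higher number (0.17 log units; within the scatter) from compound 2 to compound 4, 1.7-fold (0.23 log units) apart, within the scatter of two such steps. Among these compounds, this rests on only two pairs, so it does not show that the change would behave alike on any further core, and it does not fix the size of the step, which lies beyond the scatter on one core and within it on the other.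

The compounds shown leave open how other amines on this aromatic carbon, such as morpholine, pyrrolidine or a piperazine without the methyl group, would compare with dimethylamino on either core. They also leave open what separates the two cores themselves, and no pair shown isolates the fluorophenyl cap from the substituted piperidine.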